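Series notes: acyl sulfonamide to carboxylic acid at the amine side chain

The source may hold more compounds than are shown below. What is called first, only, known or untested is meant among the compounds shown, and "the series" means these compounds.

Measured compounds:
- compound 1 `CCOc1ccccc1-c1ccc(-c2nc3cnccc3c(N[C@@H]3CCOC3=O)c2C#N)cc1`: 2.7
- compound 2 `CC[C@@H](Nc1c(C#N)c(-c2ccc(-c3cccc(C)c3F)cc2)nc2cnccc12)C(=O)O`: 2.1
- compound 3 `CCOc1ccccc1-c1ccc(-c2nc3cnccc3c(N[C@H](CC)C(=O)NS(=O)(=O)C3CC3)c2C#N)cc1`: 2.3

In a physicochemical assay for lipophilicity, read by HPLC, at pH 7.5 (on this read-out lower numbers stand for lower lipophilicity and higher numbers for higher lipophilicity), compound 3 stands second highest of the three numbers; its nearest neighbour is compound 2 with 2.1, a gap within the scatter, and its furthest is compound 1 with 2.7, a gap beyond the scatter. Among the measured compounds shown here, the one step recorded so far is a number 0.40 log units lower from compound 1 to compound 3 (beyond the scatter), a modest move that concerns a different exchange and does not bear directly on the present one.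

Compound 4 `CCOc1ccccc1-c1ccc(-c2nc3cnccc3c(N[C@H](CC)C(=O)O)c2C#N)cc1` is compound 3 with the change (hydroxy in place of (cyclopropylsulfonyl)amino on a carbonyl carbon). For the measured compounds named here, no measured pair shows this exact exchange. Compound 2, which also carries a carboxy group on its side chain but a different aryl group, gives 2.1, within the scatter of compound 3. A step in this assay is therefore expected to be small, at most a modest lowering, estimated as a number 0.30 log units lower from compound 3 to compound 4 (within the scatter). For compound 4 the expected value in this assay is 2, with a range from 1.5 to 2.5.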

Compound 4, distribution coefficient: 2.1
Compound 4: the middle estimate sits 0.10 log units below what was measured; measured number inside the range.
By their numbers in this assay, from the lowest: compounds 2, 4 and 3 (each within the scatter of the next); then compound 1.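

In this assay, hydroxy in place of (cyclopropylsulfonyl)amino on a carbonyl carbon gives a number 0.20 log units lower from compound 3 to compound 4 (within the scatter) and so does not separate the carboxylic acid from the acyl sulfonamide on this reading. With the 1-carboxypropyl group on the nitrogen held constant, 2-ethoxyphenyl in place of 2-fluoro-3-methylphenyl gives no change at the digits printed from compound 2 to compound 4 (within the scatter) and leaves the two acids together. The clear separation in this set lies with the group on the nitrogen on an aromatic ring, where 1-carboxypropyl in place of 2-oxooxolan-3-yl gives a number 0.60 log units lower from compound 1 to compound 4 (beyond the scatter) as the largest step here.

From the compounds shown here alone, whether a primary amine or a longer chain ending in a carboxylic acid at this nitrogen would read like compound 4 remains open. The data shown give no measured reason for any of these steps.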